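A few compounds are considered here, and "the series" means these few. Any claim that something is new, unique, unknown or untested is made for them only; others in the source may bear on it.

Of the compounds shown here, two with the same sulfonamide core have been measured so far. Compound 1 `O=S(=O)(NCCCCNCc1ccc(Br)cc1)c1cc(C(F)(F)F)cc(C(F)(F)F)c1` gives 2200 nM in a functional assay on BE(2)-C cells (Homo sapiens) for inhibition, read by MTT assay, with a stated time of 72 h (a higher number here means a weaker inhibitor of growth, a lower number a stronger inhibitor of growth), and compound 2 `COc1ccc(CNCCCNS(=O)(=O)c2cc(C(F)(F)F)cc(C(F)(F)F)c2)cc1OC` gives 3600 nM in the same assay. The two values sit within the usual scatter of each other, so neither compound can be called the stronger inhibitor of growth on these numbers alone. Compound 3 `COc1ccc(CNCCCNS(=O)(=O)c2cc(C(F)(F)F)cc(C(F)(F)F)c2)cc1` has not yet been measured. Relative to compound 1, the change is (4-methoxybenzyl)amino in place of ((4-bromobenzyl)amino)methyl on a saturated chain carbon, three bonds along the chain from a sulfonamide nitrogen. Among the compounds with values here, no step between two measured compounds isolates this change, so the expectation for compound 3 rests on compound 1 giving 2200 nM and compound 2 giving 3600 nM, both of which carry a closely related benzylamine. Because compound 2 gives 3600 nM with a propyl linker and a methoxy-bearing benzyl group, the step from compound 1 to compound 3 is expected to be small, a 1.4-fold higher number from compound 1 to compound 3 (0.13 log units; within the scatter), not beyond the scatter. Compound 3 is therefore estimated at 3000 nM, with a range from 1200 nM to 7500 nM.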

Compound 3, concentration for 50% growth inhibition: 2800 nM
Compound 3: middle estimate off by 1.1-fold (0.03 log units), on the high side; low and high end bracket the measured number.
By their numbers in this assay, from the lowest: compounds 1, 3 and 2 (each within the scatter of the next).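

Within the data shown here, the step from compound 2 gives the first direct reading on a single ring substituent: with hydrogen in place of methoxy on an aromatic carbon, this assay shows a 1.3-fold lower number from compound 2 to compound 3 (0.11 log units; within the scatter), so this methoxy group can be absent without a difference the assay can resolve. The exchange of ((4-bromobenzyl)amino)methyl for (4-methoxybenzyl)amino on a saturated chain carbon, three bonds along the chain from a sulfonamide nitrogen, gives a 1.3-fold higher number from compound 1 to compound 3 (0.10 log units; within the scatter), so this larger exchange also stays within the scatter. No measurement at hand explains either result.

That exchange alters the chain and the ring substituent together, so the contribution of each cannot be judged alone. On these data alone, it remains open whether a hydroxyl group or a nitrile on the ring, or a longer chain, would give a number beyond the scatter.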